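The source may report more compounds than this note shows. Statements on the series, on what has been measured and on what is new or still open speak of the compounds shown alone.

Measured so far:
compound 1 `Cc1ccc(/C=C2\CN(Cc3cn(Cc4ccccc4F)nn3)C/C(=C\c3ccc(C)cc3)C2=O)cc1` — 10000 nM
compound 2 `COc1ccc(/C=C2\CN(Cc3cn(Cc4ccccc4Cl)nn3)C/C(=C\c3ccc(OC)cc3)C2=O)cc1` — > 100000 nM
compound 3 `COc1ccc(/C=C2\CN(Cc3cn(Cc4ccccc4F)nn3)C/C(=C\c3ccc(OC)cc3)C2=O)cc1` — 67200 nM

In a functional assay on MDA-MB-231 cells (Homo sapiens) for cytotoxicity, read by MTT assay, with a stated time of 24 h (on this read-out higher numbers stand for weaker inhibition and lower numbers for stronger inhibition), compound 1 gives 10000 nM, the lowest of the two numbers given; compound 3 gives 67200 nM. The difference between the cores of compound 1 and compound 3 is not broken down here. For compound 2 the reading is a limit of this assay, not a number, as noted in the limit of > 100000 nM in this assay, at which 1 of the 3 values shown sits. The change chloro in place of fluoro on an aromatic carbon produced an at least 1.4-fold higher number from compound 3 to compound 2 (0.17 log units; that floor lies within the scatter), a floor that lies within the scatter.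

Compound 4 `Cc1ccc(/C=C2\CN(Cc3cn(Cc4ccccc4Cl)nn3)C/C(=C\c3ccc(C)cc3)C2=O)cc1` carries the same change against compound 1, (chloro in place of fluoro on an aromatic carbon). From that one earlier step, a small or negligible shift is expected: a 1.4-fold higher number from compound 1 to compound 4 (0.15 log units; within the scatter). Compound 4 is therefore expected to give about 14000 nM in this assay, with a range from 5000 nM to 40000 nM.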

Compound 4, half-maximal inhibitory concentration: 29000 nM
Compound 4: middle estimate off by 2.1-fold (0.32 log units), on the low side; low and high end bracket the measured number.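

In this assay, chloro in place of fluoro on an aromatic carbon gives a 2.9-fold higher number from compound 1 to compound 4 (0.46 log units; beyond the scatter). This step agrees with the earlier one, which is only a floor, but it does not show that the change carries across the two cores with a fixed size: the same change on two cores in this assay, an at least 1.4-fold higher number (0.17 log units; that floor lies within the scatter) from compound 3 to compound 2 and a 2.9-fold higher number (0.46 log units; beyond the scatter) from compound 1 to compound 4; the limit leaves it open whether they differ. The reading for compound 2 is a limit and not a number, so that step has no upper bound: the limit of > 100000 nM in this assay, at which 1 of the 4 values shown sits.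

Still open, as far as these compounds go, is how bromo or trifluoromethyl would read at the same place on the benzyl group. Also open, from the compounds shown here alone, is whether the change behaves alike on a core carrying a dimethylamino group or a carboxylic acid in place of the methyl or methoxy groups.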